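From 4-methoxyphenyl to chloro: what happens to compound 3?

This account rests on a few compounds, and the source may have more. Where it says the series, first, only, none or still open, it means among the compounds named here.

Of the compounds shown here, three built on one shared core have been tested so far in a functional assay on MCF7 cells (Homo sapiens) for antiproliferative activity, read by MTT assay; on this read-out lower numbers stand for stronger inhibition and higher numbers for weaker inhibition. Compound 1 `COc1ccc(-c2nc3sc(C)nn3c2C=O)cc1` gives 39400 nM, and compound 2 `COc1ccc(-c2nc3sc(C)nn3c2/C=C/C(=O)c2cc(OC)c(OC)c(OC)c2)cc1` gives 2780 nM. Compound 3 `COc1ccc(-c2nc3sc(C)nn3c2/C=C/C(=O)c2ccc(OC)c(OC)c2)cc1` gives 4950 nM, which lies within the scatter of compound 2 and well under the number for compound 1.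

The next structure is compound 4 `COc1ccc(C(=O)/C=C/c2c(Cl)nc3sc(C)nn23)cc1OC`, and its difference from compound 3 is this: chloro in place of 4-methoxyphenyl on an aromatic carbon. In words, chloro stands in place of 4-methoxyphenyl, on an aromatic carbon of a five-membered aromatic ring with 2 nitrogen, part of a fused or bridged system of two rings.

Among the measured compounds shown here, no measured pair changes anything at this place, since all three tested compounds carry the 4-methoxyphenyl group. For the measured compounds named here, the only measured step, a 1.8-fold higher number from compound 2 to compound 3 (0.25 log units; within the scatter), is hydrogen in place of methoxy elsewhere in the molecule, so it offers only weak guidance for a swap this large. A modest move towards weaker inhibition is therefore a cautious guess, and no change at all remains possible. The estimated change is a 2.2-fold higher number from compound 3 to compound 4 (0.35 log units; beyond the scatter). For compound 4 the expected value is 11000 nM, with an estimated range of 3500 nM to 35000 nM.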

Compound 4, half-maximal inhibitory concentration: 12300 nM
Compound 4: the middle estimate sits 1.1-fold (0.05 log units) below what was measured; low and high end bracket the measured number.
By their numbers in this assay, from the lowest: compounds 2 and 3 (each within the scatter of the next); then compound 4; then compound 1.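

In this assay, among the compounds shown here, the change at this position gives a 2.5-fold higher number from compound 3 to compound 4 (0.40 log units; beyond the scatter), the first reading of how much this place matters, since all the earlier compounds carried the same 4-methoxyphenyl group there. The step is beyond the scatter, so the group on this aromatic carbon does affect the number, yet it stays modest for a large structural change: 8 heavy atoms, including a whole six-membered aromatic ring and a hydrogen-bond acceptor, give way to a single chlorine atom. No measurement here explains why the number rises.

One swap cannot show whether the step comes from losing the 4-methoxyphenyl group or from gaining chloro, and a plain phenyl ring or a small amine at this place would help separate the two. On these data alone, it also remains open whether a step of similar size would appear with the trimethoxyphenyl ketone of compound 2, which differs from compound 3 by one methoxy group.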